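This account rests on a few compounds, and the source may have more. Where it says the series, first, only, none or still open, it means among the compounds named here.

In a functional assay on HCT-116 cells (Homo sapiens) for antiproliferative activity, read by resazurin assay, with a stated time of 5 days (on this read-out higher numbers stand for weaker inhibition and lower numbers for stronger inhibition), three compounds sharing one core differ only in the group on the carbonyl carbon. Compound 1 (`COCc1ccc(C(=O)NCc2ccc3cc(C(=O)NO)sc3c2F)o1`) gives 310 nM, compound 2 (`Cc1ncoc1C(=O)NCc1ccc2cc(C(=O)NO)sc2c1F`) gives 210 nM and compound 3 (`O=C(NCc1ccc2cc(C(=O)NO)sc2c1F)c1ccccc1`) gives 980 nM. Compound 3, with its phenyl, thus has the highest number and is the weakest of the three. The measured steps are a 3.2-fold higher number from compound 1 to compound 3 (0.50 log units; beyond the scatter) and a 4.7-fold higher number from compound 2 to compound 3 (0.67 log units; beyond the scatter), both modest, while a 1.5-fold lower number from compound 1 to compound 2 (0.17 log units; within the scatter) stays within the scatter.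

Compound 4 (`COc1ccccc1C(=O)NCc1ccc2cc(C(=O)NO)sc2c1F`) has methoxy in place of hydrogen on an aromatic carbon of the phenyl of compound 3, ortho to a large group: methoxy in place of hydrogen on an aromatic carbon. Going by the values given here, no measured step adds a group to that phenyl. The two modest steps replace the whole group, so they bear on this change only loosely. In this assay the expected change is therefore small, a 1.2-fold lower number from compound 3 to compound 4 (0.09 log units; within the scatter), and is not expected to exceed the scatter. For compound 4 the estimated value is 800 nM, with an expected range from 350 nM to 1800 nM.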

Compound 4, half-maximal inhibitory concentration: 1200 nM
The estimate for compound 4 lay 1.5-fold (0.18 log units) below the measured number; low and high end bracket the measured number.
By their numbers in this assay, from the lowest: compounds 2 and 1 (each within the scatter of the next); then compounds 3 and 4 (each within the scatter of the next).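

In this assay the first direct test of a group added to the phenyl of compound 3, methoxy on an aromatic carbon ortho to a large group, gives a 1.2-fold higher number from compound 3 to compound 4 (0.09 log units; within the scatter) and so shows no change that can be told from the scatter. The 2-methoxyphenyl thus stays apart from the two other groups on the carbonyl carbon, with a 5.7-fold higher number from compound 2 to compound 4 (0.76 log units; beyond the scatter) and a 3.9-fold higher number from compound 1 to compound 4 (0.59 log units; beyond the scatter) as modest steps, so this one addition does not close the distance that the plain phenyl showed. Nothing given here accounts for this result.

The compounds shown leave open whether this finding holds only for methoxy or also for an amine or a carboxylic acid at the same place on the phenyl. They also leave open what a longer chain, such as ethoxy, would do there.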